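The compounds below may be only part of what the source reports. "The series", "measured", "known", "first", "only" and "open" are said of these compounds alone.

Compound 1 `Nc1ccc(S(=O)(=O)N2CCN(c3ncc(C(O)(C(F)(F)F)C(F)(F)F)cc3C3CC3)CC2)cn1` gives 38 mL.min-1.g-1 in an ADME assay (liver) for metabolic stability, with Liver microsome (Homo sapiens) as the target, using microsomes and NADPH, with a stated time of 30 min, tested at 1 uM; on this read-out lower numbers stand for slow clearance and higher numbers for fast clearance. Compound 2 `CC(C)n1cc(-c2cc(C(O)(C(F)(F)F)C(F)(F)F)cnc2N2CCN(S(=O)(=O)c3ccc(N)nc3)CC2)cn1` gives 38 mL.min-1.g-1. Compound 3 `Nc1ccc(S(=O)(=O)N2CCN(c3ncc(C(O)(C(F)(F)F)C(F)(F)F)cc3-c3cccnc3)CC2)cn1` gives 17 mL.min-1.g-1.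

Compound 2 stands level with compound 1 at the digits shown, the two together the highest of the three numbers; its only step beyond the scatter is a 2.2-fold lower number from compound 2 to compound 3 (0.35 log units; beyond the scatter). Compound 4 `Nc1ccc(S(=O)(=O)N2CCN(c3ncc(C(O)(C(F)(F)F)C(F)(F)F)cc3-c3ccc4scnc4c3)CC2)cn1` differs from compound 2 in one place: 1,3-benzothiazol-5-yl in place of 1-isopropyl-1H-pyrazol-4-yl on an aromatic carbon. The closest measured precedent is the replacement of the same group by pyridin-3-yl, a 2.2-fold lower number from compound 2 to compound 3 (0.35 log units; beyond the scatter), a modest drop, and a 2.2-fold lower number from compound 1 to compound 3 (0.35 log units; beyond the scatter) points the same way. Within the data shown here, the entering group, however, also carries a six-membered aromatic ring of carbon only, for which no measured step exists. For compound 4 a number close to that of compound 2 is therefore expected, a 1.1-fold lower number from compound 2 to compound 4 (0.04 log units; within the scatter), estimated at 35 mL.min-1.g-1 with a range from 15 mL.min-1.g-1 to 80 mL.min-1.g-1.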

Compound 4, intrinsic clearance in microsomes: 39 mL.min-1.g-1
The estimate for compound 4 lay 1.1-fold (0.05 log units) below the measured number; measured number inside the range.
By their numbers in this assay, from the lowest: compound 3; then compounds 1, 2 and 4 (each within the scatter of the next).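

The lower number of compound 3 is not shared by every aromatic ring at this position: in this assay, 1,3-benzothiazol-5-yl in place of pyridin-3-yl gives a clear rise (a 2.3-fold higher number from compound 3 to compound 4 (0.36 log units; beyond the scatter)). The same group cannot be told apart from 1-isopropyl-1H-pyrazol-4-yl (a 1.0-fold higher number from compound 2 to compound 4 (0.01 log units; within the scatter)) or from cyclopropyl (a 1.0-fold higher number from compound 1 to compound 4 (0.01 log units; within the scatter)), even though it brings a second ring. Nothing at hand explains why pyridin-3-yl stands apart. On these data alone, whether a plain phenyl ring, or pyridin-3-yl carrying an amine, would share the number of compound 3 stays open.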